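A few compounds are considered here, and "the series" means these few. Any claim that something is new, unique, unknown or untested is made for them only; others in the source may bear on it.

Measured so far:
- Compound 1, `COc1ccccc1/C=c1/[nH]c(=O)/c(=C\c2ccccc2OC)n(C)c1=O`: in a functional assay on Huh-7 cells (Homo sapiens) for cytotoxicity, read by CCK-8 assay, with a stated time of 72 h (a higher number here means a weaker inhibitor, a lower number a stronger inhibitor), compound 1 gives "not active" (no number reported).
- Compound 2, `COc1ccccc1/C=c1/[nH]c(=O)/c(=C\c2cccc(Cl)c2Cl)[nH]c1=O`: in this assay compound 2 gives "not active" (no number reported).
- Compound 3, `C=CCn1c(=O)/c(=C\c2ccccc2Cl)[nH]c(=O)/c1=C\c1ccccc1OC`: in this assay compound 3 gives 6400 nM.

Compound 3 is the only one of the three for which a number is reported at all; compound 1 and compound 2 were each reported as not active, with no value attached, so nothing can be said about how far apart they and compound 3 really lie. Compound 3 therefore stands alone as the single fixed point in this assay.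

Compound 4, `C=CCn1c(=O)/c(=C\c2cc(Br)ccc2F)[nH]c(=O)/c1=C\c1ccccc1OC`, is the next compound. It differs from compound 3 in one place: 5-bromo-2-fluorophenyl in place of 2-chlorophenyl on a double-bonded chain carbon bound to an aromatic carbon. Among the measured compounds shown here, no pair of measured compounds shows what this kind of swap does in this assay, so there is no measured step to lean on. For the measured compounds named here, with only a single number available and a change that keeps the rest of the molecule untouched, the expectation is a step no larger than the usual scatter, in no particular direction. Compound 4 is therefore expected to give about 6000 nM, somewhere between 2500 nM and 15000 nM. That estimate means a step from compound 3 to compound 4 of a 1.1-fold lower number from compound 3 to compound 4 (0.03 log units; within the scatter), expected to be within the scatter.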

Compound 4, half-maximal inhibitory concentration: "not active" (no number reported)
Compound 4: no number reported, so the estimate cannot be set against anything.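

In this assay, among the compounds shown here, compound 4 is reported as not active with no number, so no step from compound 3 to compound 4 can be read. Nothing measured here accounts for this result. The compounds shown leave open how far compound 4 really lies from compound 3.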